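The source may hold more compounds than are shown below. What is called first, only, known or untested is meant among the compounds shown, and "the series" means these compounds.

Working notes on the ether series, read in a functional assay on ACHN cells (Homo sapiens) for antiproliferative activity, read by sulforhodamine B assay; a lower number here means a stronger inhibitor of growth, a higher number a weaker inhibitor of growth. Compound 2 `CC(C)=CCOc1cccc(O)c1C(=O)/C=C/c1ccc(O)cc1` gives only a limit, > 30000 nM, not a number. Compound 1 `CCCCCCOc1cccc(O)c1C(=O)/C=C/c1ccc(O)cc1` likewise gives only a limit, > 30000 nM. Both therefore sit at the limit of > 30000 nM in this assay, at which 2 of the 3 values shown sit. Compound 3 `CCC(CC)COc1cccc(O)c1C(=O)/C=C/c1ccc(O)cc1` alone gives a number, 3370 nM.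

Compound 4 `O=C(/C=C/c1ccc(O)cc1)c1c(O)cccc1OCc1ccccc1` carries a new change: phenyl in place of 2-methylprop-1-en-1-yl on a saturated chain carbon bound to an oxygen on an aromatic ring.

Among the measured compounds shown here, no measured step covers phenyl directly. The nearest guides are an at least 8.9-fold lower number from compound 2 to compound 3 (0.94 log units; beyond the scatter) and an at least 8.9-fold lower number from compound 1 to compound 3 (0.94 log units; beyond the scatter), both with pentan-3-yl entering at the same place. The remaining step, a step that the two limits leave unreadable from compound 1 to compound 2, gives no size. Compound 3 shows that a change at this place can bring the number off the limit, so a lower number is expected, though a result at the limit remains quite possible. The expected move is an at least 2.5-fold lower number from compound 2 to compound 4 (0.39 log units; beyond the scatter), no larger than the measured steps. The estimate for compound 4 is 12000 nM, with an expected range of 4000 nM to 35000 nM.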

Compound 4, concentration for 50% growth inhibition: > 30000 nM
Compound 4 was reported as a limit; the forecaster's own chance of this, stated with the estimate: 45%; middle value at least 2.5-fold (0.39 log units) away from the limit.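

In this assay compound 4 gives > 30000 nM, which is a limit and not a number. Phenyl on the saturated chain carbon bound to the oxygen therefore does not repeat what pentan-3-yl does at this place, and the one readable step is an at least 8.9-fold higher number from compound 3 to compound 4 (0.94 log units; beyond the scatter), while the steps to compound 4 from compound 1 and compound 2 cannot be read, since both ends are limits. Compound 3 is now the only ether shown to leave the limit, and the series stands as follows: the limit of > 30000 nM in this assay, at which 3 of the 4 values shown sit.

The compounds shown leave open whether cyclohexyl or a longer branched chain at this place would also give a number, and whether such a group would fall on either side of compound 3. As far as these compounds go, how far compound 1, compound 2 and compound 4 lie from one another also remains unknown.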